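The compounds below may be only part of what the source reports. "The series", "measured", "known", "first", "only" and "open" are said of these compounds alone.

Measured compounds: compound 1 `CCCN(CCC)c1nc(N2CCN(C(=O)c3ccco3)[C@@H]3CCCC[C@@H]32)nc2cc(OC)c(OC)cc12`, compound 2 `CCCCCC(=O)N1CCN(c2nc(N)c3cc(OC)c(OC)cc3n2)[C@@H]2CCCC[C@@H]21` and compound 3 `COc1cc2nc(N3CCN(C(C)=O)[C@H]4CCCC[C@H]43)nc(N)c2cc1OC`. In an assay on CHO cells for displacement of a labelled ligand from Alpha-1D adrenergic receptor (Homo sapiens), with a stated time of 30 min (a lower number here means a stronger inhibitor, a higher number a weaker inhibitor), compound 1 gives 0.0631 nM; compound 2 gives 3.72 nM; compound 3 gives 105 nM.

Compound 1 stands lowest of the three numbers, well beyond the scatter from either other compound. Among the measured compounds shown here, the single measured step, a 28-fold higher number from compound 2 to compound 3 (1.45 log units; beyond the scatter), concerns the acyl chain only. Compound 4 `CCCN(CCC)c1nc(N2CCN(C(=O)c3ccco3)[C@H]3CCCC[C@H]32)nc2cc(OC)c(OC)cc12` differs from compound 1 in this way: the two compounds have the same atoms and bonds and differ only in configuration as drawn: 2 of 2 stereo elements differ (all stereocentres are inverted: mirror images); a stereocentre at a saturated ring carbon is drawn R in compound 1 and S in compound 4; a stereocentre at a saturated ring carbon is drawn S in compound 1 and R in compound 4. For the measured compounds named here, no measured step touches a change of configuration, so the size and direction of the change rest on no direct precedent here. Compound 4 is nevertheless expected to give a higher number than compound 1, a step of a 16-fold higher number from compound 1 to compound 4 (1.20 log units; beyond the scatter). Compound 4 is estimated at 1 nM, within a range from 0.08 nM to 20 nM.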

Compound 4, inhibition constant: 5.13 nM
Compound 4: middle estimate off by 5.1-fold (0.71 log units), on the low side, and the stated range covers the measured number.
By their numbers in this assay, from the lowest: compound 1; then compounds 2 and 4 (each within the scatter of the next); then compound 3.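

In this assay the mirror-image pair gives an 81-fold higher number from compound 1 to compound 4 (1.91 log units; beyond the scatter), so the number at this pair of saturated ring carbons depends on configuration. The earlier step concerned only the acyl chain, whereas this one shows a large shift with no group leaving or entering: the fact that compounds 1 and 4 differ only in the configuration as drawn

The compounds shown leave open which of the two stereocentres carries the shift, since both are inverted together. They also leave open whether it would persist with a benzoyl group as the acyl group.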